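The source may report more compounds than this note shows. Statements on the series, on what has been measured and on what is new or still open speak of the compounds shown alone.

Compound 1 `C[C@@H](Cn1ccc(-c2ccc(C#N)c(Cl)c2)n1)NC(=O)c1ccccc1` has no number of its own in an ADME assay on L02 cells (Homo sapiens) for cytotoxicity, read by CCK-8 assay, with a stated time of 6 days; a lower number here means a stronger inhibitor, a higher number a weaker inhibitor; for compound 1 the result reads "not determined" (no result reported). Going by the values given here, the only value in this assay comes from compound 2 `CC(O)c1ccc(C(=O)N[C@@H](C)Cn2ccc(-c3ccc(C#N)c(Cl)c3)n2)cc1`, which gives a limit of > 30000 nM. Compound 1 thus stands beside a single limit, (the limit of > 30000 nM in this assay, at which 1 of the 2 values shown sits). Compound 3 `C[C@@H](Cn1ccc(-c2ccc(C#N)c(Cl)c2)n1)NC(=O)c1cccc(OCC(O)CO)c1` differs from compound 1 by 2,3-dihydroxypropoxy in place of hydrogen on an aromatic carbon. No step between measured compounds is shown, so in this assay no shift beyond the scatter is expected from this change. Compound 3 is expected to return 30000 nM, within 10000 nM to 100000 nM, most likely again as a limit.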

Compound 3, half-maximal inhibitory concentration: > 30000 nM
Compound 3: only a limit was reported (the forecaster's own chance of this, stated with the estimate: 85%); the middle value lies on the limit itself.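

No step can be read from these results: compound 1 has no number, while compound 2 and compound 3 each give only a limit. The compounds shown leave open what actual half-maximal inhibitory concentration any of them has in this assay.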